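The compounds below may be only part of what the source reports. "The series", "measured", "known", "first", "only" and "open" are said of these compounds alone.

Among the compounds with values here, compound 1 `CC(C)=CC[C@@H]1C[C@]2(CC=C(C)C)C(=O)[C@@](CC=C(C)C)(C(=O)C(C(=O)c3ccccc3)=C2O)C1(C)C` is the only member of this small set with a definite number in a functional assay on HCT-116 cells (Homo sapiens) for inhibition; on this read-out higher numbers stand for weaker inhibition and lower numbers for stronger inhibition: compound 1 gives 6.87 ug/mL. Compound 2 `CC(C)=CCC/C(C)=C/C[C@@H]1C[C@@]2(C/C=C(\C)CCC=C(C)C)C(=O)CC(=O)[C@](CC=C(C)C)(C2=O)C1(C)C` is a different matter, since in this assay compound 2 reaches only a limit of the measurement, > 20 ug/mL, and no number. That sets compound 1 apart as the single quantified point, with the other value sitting at the limit of > 20 ug/mL in this assay, at which 1 of the 2 values shown sits.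

The step of interest leads from compound 1 to compound 3 `CC(C)=CC[C@@H]1C[C@]2(CC=C(C)C)C(=O)[C@@](CC=C(C)C)(C(=O)C(C(=O)c3ccc(O)c(O)c3)=C2O)C1(C)C`, and the change is confined to one position: 3,4-dihydroxyphenyl in place of phenyl on a carbonyl carbon. Everything else in the shared core is kept. Within the data shown here, because no pair of measured compounds differs in a single place, there is no measured step to lean on, and the size of the effect has to be estimated from the structural change alone. Compound 3 is expected to show a modest gain in inhibition, with the step of a 1.7-fold lower number from compound 1 to compound 3 (0.23 log units; within the scatter) judged to lie at the edge of the usual scatter rather than well beyond it. Compound 3 is therefore estimated at 4 ug/mL, within a range from 1.5 ug/mL to 12 ug/mL.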

Compound 3, half-maximal inhibitory concentration: 9.22 ug/mL
Beside the measured number, compound 3's estimate is 2.3-fold (0.36 log units) below it, within the range that was stated.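

In this assay, within the data shown here, the exchange of phenyl for 3,4-dihydroxyphenyl on a carbonyl carbon gives the only step that can be read at this position (a 1.3-fold higher number from compound 1 to compound 3 (0.13 log units; within the scatter)), and the two compounds cannot be told apart on this read-out. Unlike the single quantified value available earlier, this pair shows that the benzoyl position can take the larger 3,4-dihydroxyphenyl group, with its hydrogen-bond donors and acceptors, without a change beyond the scatter, while everything else in the shared core stays the same. None of the evidence at hand bears on this result or offers a reason for it.

As far as these compounds go, it remains open whether a single hydroxyl group on the ring, an amine or a carboxylic acid on the ring, or a longer chain on the carbonyl carbon in place of the ring would move the number beyond the scatter. From the compounds shown here alone, it is also open whether the same exchange would read alike on a different core or in another assay, since this one step rests on a single pair of compounds.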